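From an amino group to a hydroxy group

A few compounds are considered here, and "the series" means these few. Any claim that something is new, unique, unknown or untested is made for them only; others in the source may bear on it.

Measured so far in a functional assay on NCI-H1975 cells (Homo sapiens) for antiproliferative activity (a lower number here means a stronger inhibitor, a higher number a weaker inhibitor), are these two compounds:
- Compound 1 `Cc1c2c(n3c1CCN(C(=O)C(C)(C)N)C[C@@H](C)[C@H](C)Nc1cc-3ccc1C(N)=O)CC(C)(C)CC2=O` gives 21 nM
- Compound 2 `Cc1c2c(n3c1CCN(C(=O)C1(N)CCCC1)C[C@@H](C)[C@H](C)Nc1cc-3ccc1C(N)=O)CC(C)(C)CC2=O` gives 26 nM

Compound 2 stands level with compound 1 within the scatter. That single measured step (a 1.2-fold higher number from compound 1 to compound 2 (0.09 log units; within the scatter)) exchanges one amino-bearing group for another. Compound 3 (`Cc1c2c(n3c1CCN(C(=O)[C@@H](O)C(C)C)C[C@@H](C)[C@H](C)Nc1cc-3ccc1C(N)=O)CC(C)(C)CC2=O`) differs from compound 2 in another way (1-hydroxy-2-methylpropyl in place of 1-aminocyclopentyl on a carbonyl carbon), with 1-hydroxy-2-methylpropyl in place of 1-aminocyclopentyl on a carbonyl carbon. Among the compounds with values here, no measured compound lacks the amino group, so the step from compound 1 (a 1.2-fold higher number from compound 1 to compound 2 (0.09 log units; within the scatter)) is only a weak guide. No shift beyond the scatter is therefore expected in this assay (a 1.2-fold higher number from compound 2 to compound 3 (0.09 log units; within the scatter)), with either direction possible. The estimate for compound 3 is 32 nM within an expected range of 10 nM to 100 nM until it is measured.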

Compound 3, half-maximal inhibitory concentration: 31 nM
Beside the measured number, compound 3's estimate is 1.0-fold (0.01 log units) above it, and the stated range covers the measured number.
By their numbers in this assay, from the lowest: compounds 1, 2 and 3 (each within the scatter of the next).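

In this assay, the step of a 1.2-fold higher number from compound 2 to compound 3 (0.08 log units; within the scatter) and the step of a 1.5-fold higher number from compound 1 to compound 3 (0.17 log units; within the scatter) both swap an amino-bearing group for 1-hydroxy-2-methylpropyl on the carbonyl carbon. Across these three compounds, then, an amino group is not required at this place: a hydroxy-bearing group without a ring gives a number within the scatter of both. Nothing available here explains this result. Still open, from the compounds shown here alone, is how a group with neither amino nor hydroxy, such as a plain methyl or a methoxymethyl, would read here. Going by these compounds, the mirror-image form of the defined stereocentre also remains open.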